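A few compounds are considered here, and "the series" means these few. Any claim that something is new, unique, unknown or untested is made for them only; others in the source may bear on it.

Measured so far:
Compound 1, `Cc1cnc(Nc2ccc(S(C)(=O)=O)cc2)nc1Nc1nc2ccc(Cl)cc2s1`: 4180 nM
Compound 2, `Cc1cnc(Nc2ccc(C(C)C)cc2)nc1Nc1nc2ccccc2s1`: > 50000 nM

In a functional assay on HeLa cells (Homo sapiens) for antiproliferative activity, read by MTT assay, with a stated time of 48 h (a higher number here means a weaker inhibitor, a lower number a stronger inhibitor), compound 1 gives 4180 nM, a measurable number. As far as these compounds go, compound 2 stands at the edge of what the assay can report: in this assay compound 2 gives > 50000 nM, which is a limit of the assay and not a number, so where compound 2 truly sits beyond that bound is unknown (the limit of > 50000 nM in this assay, at which 1 of the 2 values shown sits). Compound 3, `Cc1cnc(Nc2ccc(S(C)(=O)=O)cc2)nc1Nc1nc2ccccc2s1`, has not yet been measured. It differs from compound 2 in one place: methylsulfonyl in place of isopropyl on an aromatic carbon. Among the compounds with values here, no step between two measured compounds covers exactly this change, so its size is not fixed by the data. Within the data shown here, compound 1 also carries the methylsulfonyl group, but it differs from compound 3 in a second place as well, so its value shows only that a measurable number is possible with this group present. The expected step is an at least 5.5-fold lower number from compound 2 to compound 3 (0.74 log units; beyond the scatter), in the direction of stronger inhibition. Compound 3 is estimated at 9000 nM, with a likely range from 2500 nM to 40000 nM.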

Compound 3, half-maximal inhibitory concentration: 460 nM
The estimate for compound 3 lay 20-fold (1.29 log units) above the measured number, outside the stated range (below it).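

With the rest of the molecule unchanged, methylsulfonyl in place of isopropyl on this aromatic carbon, para to a large group, gives in this assay an at least 100-fold lower number from compound 2 to compound 3 (2.03 log units; beyond the scatter), so this one place can decide between a measurable number and none. The true size of that step has no upper end, because compound 2 carries a limit of the assay and not a number: the limit of > 50000 nM in this assay, at which 1 of the 3 values shown sits.

With the methylsulfonyl group kept, hydrogen in place of chloro on an aromatic carbon gives a 9.1-fold lower number from compound 1 to compound 3 (0.96 log units; beyond the scatter), so chloro is not needed for a measurable number here, and in this pair the compound without it is the stronger inhibitor.

The compounds shown hold only isopropyl and methylsulfonyl at the first place, so they leave open how an amine, a carboxylic acid or a sulfonamide would read there. They also leave open whether chloro would lower or raise the number alongside isopropyl, and how a smaller halogen such as fluoro would compare with chloro at its place.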